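The source may hold more compounds than are shown below. What is called first, only, known or untested is meant among the compounds shown, and "the series" means these compounds.

Compound 2 `Nc1ccccc1NC(=O)/C=C/c1ccc(CSCCc2ccccc2)cc1` and compound 1 `Nc1ccccc1NC(=O)/C=C/c1ccc(CSc2ccc(F)cc2)cc1` share one core; in a functional assay on SMMC-7721 cells (Homo sapiens) for inhibition, read by CCK-8 assay, with a stated time of 72 h, tested at 8 uM (on this read-out lower numbers stand for less inhibition of growth and higher numbers for more inhibition of growth at the one concentration tested), compound 2 gives 15.8% and compound 1 gives 15.4%. The change between them, (4-fluorophenyl in place of phenethyl on a sulfur), makes a step of a number 0.4 percentage points lower from compound 2 to compound 1 (within the scatter). Compound 3 `Nc1ccccc1NC(=O)c1ccc(CSCCc2ccccc2)cc1` carries another core and in this assay compound 3 gives 77.9%, the highest of the three; the difference between the two cores is not broken down here. Compound 4 `Nc1ccccc1NC(=O)c1ccc(CSc2ccc(F)cc2)cc1` is the counterpart of compound 3 with the same change, (4-fluorophenyl in place of phenethyl on a sulfur), at the same place on a sulfur. Because the earlier occurrence of this change gave a number 0.4 percentage points lower from compound 2 to compound 1 (within the scatter), the expected step is a number 2.9 percentage points lower from compound 3 to compound 4 (within the scatter). The wider range rests on the core of compound 3 differing from that of compound 2. Compound 4 is estimated at 75%, expected between 55% and 90%.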

Compound 4, percent growth inhibition at one concentration: 81.9%
The estimate for compound 4 lay 6.9 percentage points below the measured number; measured number inside the range.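

In this assay 4-fluorophenyl in place of phenethyl on a sulfur gives a number 4 percentage points higher from compound 3 to compound 4 (within the scatter) on the second core. Set beside the earlier step, the change carries from one core to the other with no difference that can be told apart: the same change on two cores in this assay, a number 0.4 percentage points lower (within the scatter) from compound 2 to compound 1 and a number 4 percentage points higher (within the scatter) from compound 3 to compound 4, 4.4 percentage points apart, within the scatter of two such steps. This rests on two pairs tested at one concentration in one cell line, and it does not show that the change would carry to any further core.

Left open is how a group other than these two on the sulfur, such as a longer chain or a chain ending in an amine or a carboxylic acid, would read on either core. Also open, on these data alone, is whether these pairs stay level at other concentrations or in other cell lines.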